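A few compounds are considered here, and "the series" means these few. Any claim that something is new, unique, unknown or untested is made for them only; others in the source may bear on it.

Going by the values given here, compound 2 `O=C(/C=N/Nc1ccc([N+](=O)[O-])cc1[N+](=O)[O-])NCCCCCCCNc1ccnc2cc(Cl)ccc12` stands highest of the two numbers measured so far: in a functional assay on MRC5 cells (Homo sapiens) for cytotoxicity, read by colorimetric assay and MTT assay (a lower number here means that less compound is tolerated, a higher number that more compound is tolerated), compound 2 gives 11100 nM, while compound 1 `O=C(/C=N/OCc1ccc([N+](=O)[O-])cc1)NCCCCCCCNc1ccnc2cc(Cl)ccc12` gives 1700 nM, a gap beyond the usual scatter. Compound 3 `O=C(/C=N/NCc1ccccc1)NCCCCCCCNc1ccnc2cc(Cl)ccc12` differs from compound 2 in one place: benzyl in place of 2,4-dinitrophenyl on an amine nitrogen. Among the compounds with values here, no step of this kind has been measured here, so the direction rests on these two numbers alone. A moderate decrease is expected, a 2.5-fold lower number from compound 2 to compound 3 (0.39 log units; beyond the scatter), although it could still fall within the scatter. Compound 3 is therefore estimated at 4500 nM, with a range from 1300 nM to 14000 nM.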

Compound 3, half-maximal cytotoxic concentration: 14600 nM
For compound 3 the middle estimate is 3.2-fold (0.51 log units) below the measured one, and the stated range ends below it.
By their numbers in this assay, from the lowest: compound 1; then compounds 2 and 3 (each within the scatter of the next).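

In this assay, the step from 2,4-dinitrophenyl to benzyl on the amine nitrogen is a 1.3-fold higher number from compound 2 to compound 3 (0.12 log units; within the scatter), so this position takes either group without a readable difference. Benzylamino in place of (4-nitrobenzyl)oxy on the double-bonded nitrogen gives an 8.6-fold higher number from compound 1 to compound 3 (0.93 log units; beyond the scatter), so the low number of compound 1 goes with its (4-nitrobenzyl)oxy group. No measured evidence bears on the reason for either result. Open, from the compounds shown here alone, is whether a benzyloxy group on that double-bonded nitrogen would separate the oxygen link from the nitro group. Going by these compounds, the effect of a shorter chain also remains open.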